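The compounds below may be only part of what the source reports. "The series", "measured", "known", "first", "only" and "open" are said of these compounds alone.

Compound 1 `O=S(=O)(Nc1ccc2cc[nH]c2c1)c1ccc(Br)cc1`: 40100 nM
Compound 2 `O=C(Nc1ccc2cc[nH]c2c1)c1cccc(C(F)(F)F)c1`: 28200 nM

In a functional assay on T47D cells (Homo sapiens) for antiproliferative activity, read by MTT assay, with a stated time of 24 h (on this read-out higher numbers stand for weaker inhibition and lower numbers for stronger inhibition), compound 1 gives 40100 nM and compound 2 gives 28200 nM on the same read-out. These two numbers lie within the usual scatter of each other, so compound 1 cannot be ranked against compound 2.

Compound 3 `COc1ccc(S(=O)(=O)Nc2ccc3cc[nH]c3c2)cc1` keeps the core of compound 1 and differs by methoxy in place of bromo on an aromatic carbon in one place, with methoxy in place of bromo on an aromatic carbon. Among the compounds with values here, no measured pair shows what this change does, so no step beyond the scatter is expected in this assay in either direction. The estimated change is a 1.3-fold lower number from compound 1 to compound 3 (0.13 log units; within the scatter) and stays within that scatter. For compound 3 the expected value is 30000 nM with an estimated range from 10000 nM to 80000 nM on this read-out.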

Compound 3, half-maximal inhibitory concentration: 45000 nM
For compound 3 the middle estimate is 1.5-fold (0.18 log units) below the measured one; low and high end bracket the measured number.
By their numbers in this assay, from the lowest: compounds 2, 1 and 3 (each within the scatter of the next).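

In this assay the swap of bromo for methoxy on this aromatic carbon, para to a large group, gives a step (a 1.1-fold higher number from compound 1 to compound 3 (0.05 log units; within the scatter)) that lies within the scatter. This is the first pair shown that differs in one place, and on this read-out it does not separate the two groups. Nothing measured here offers an explanation for this result. Still open, as far as these compounds go, is whether any other group at this position, such as an amine or a carboxylic acid, would give a step beyond the scatter.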